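Chain extension at the oxygen next to a carbonyl group

The source may hold more compounds than are shown below. What is called first, only, known or untested is meant among the compounds shown, and "the series" means these compounds.

Measured so far:
Compound 1 `COC(=O)N1N=C(c2ccccc2)CC1c1cc(OC)c(OC)c(OC)c1` in a functional assay on HT-29 cells (Homo sapiens) for antiproliferative activity, read by MTT assay, with a stated time of 48 h (on this read-out higher numbers stand for weaker inhibition of growth and lower numbers for stronger inhibition of growth), gives 6260 nM.
Compound 2 `CCOC(=O)N1N=C(c2ccccc2)CC1c1cc(OC)c(OC)c(OC)c1` in this assay gives 8920 nM.
Compound 3 `CCOC(=O)N1N=C(c2cccc(OC)c2)CC1c1cc(OC)c(OC)c(OC)c1` in this assay gives 7860 nM.

Compound 1 and compound 2 differ by methyl in place of hydrogen on a saturated chain carbon bound to an oxygen next to a carbonyl group; this gave a 1.4-fold higher number from compound 1 to compound 2 (0.15 log units; within the scatter). Compound 2 and compound 3 differ by methoxy in place of hydrogen on an aromatic carbon, with a 1.1-fold lower number from compound 2 to compound 3 (0.05 log units; within the scatter). All three numbers sit close together. Compound 4 `CCCOC(=O)N1N=C(c2cccc(OC)c2)CC1c1cc(OC)c(OC)c(OC)c1` has not been measured; it differs from compound 3 by methyl in place of hydrogen on a saturated chain carbon, two bonds along the chain from an oxygen next to a carbonyl group. The difference between the core of compound 1 and the core of compound 3 is not broken down here. The change from compound 3 to compound 4 is the same kind of change as that from compound 1 to compound 2, but the place is not the same: in compound 2 the methyl enters on a saturated chain carbon bound to an oxygen next to a carbonyl group, in compound 4 two bonds along the chain from that oxygen. Because a 1.4-fold higher number from compound 1 to compound 2 (0.15 log units; within the scatter) stayed within the scatter, a step of similar size is expected for compound 4, estimated as a 1.2-fold higher number from compound 3 to compound 4 (0.08 log units; within the scatter) in this assay. Compound 4 is expected to give about 9500 nM, within 5000 nM to 18000 nM.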

Compound 4, concentration for 50% growth inhibition: > 10000 nM
Compound 4 was reported as a limit; the forecaster's own chance of this, stated with the estimate: 10%; middle value at least 1.0-fold (0.02 log units) away from the limit.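

In this assay compound 4 gives > 10000 nM, which is a limit of the assay and not a number. The change can therefore be read only as a floor, an at least 1.2-fold higher number from compound 3 to compound 4 (0.10 log units; that floor lies within the scatter), and beside the earlier step on the core of compound 1 it gives no firm comparison between the two cores: the same change on two cores in this assay, a 1.4-fold higher number (0.15 log units; within the scatter) from compound 1 to compound 2 and an at least 1.2-fold higher number (0.10 log units; that floor lies within the scatter) from compound 3 to compound 4; the limit leaves it open whether they differ The step on the core of compound 3 has no upper bound here, so the data show neither that the change carries over at the same size nor that its size depends on the core.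

The compounds shown leave open how a longer chain such as butyl, or a branched chain such as isopropyl, would read in this assay on either core. They also leave open whether an amide or a carboxylic acid in the place of the ester would give a value that could be read as a number on these cores.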